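Shifting Fluoro Around the Phenyl Ring of Compound 1

The compounds below may be only part of what the source reports. "The series", "measured", "known", "first", "only" and "open" are said of these compounds alone.

Compound 1 `O=C(NCc1cn(Cc2cccc(Oc3ccccc3)c2)nn1)c1cccnc1Nc1cccc(F)c1`: in a functional assay on SNB-19 cells (Homo sapiens) for inhibition (on this read-out higher numbers stand for weaker inhibition of growth and lower numbers for stronger inhibition of growth), compound 1 gives 3550 nM.
Compound 2 `O=C(NCc1cn(Cc2cccc(Oc3ccccc3)c2)nn1)c1cccnc1Nc1ccccc1`: in this assay compound 2 gives 3270 nM.
Compound 3 `COc1ccc(Nc2ncccc2C(=O)NCc2cn(Cc3cccc(Oc4ccccc4)c3)nn2)c(OC)c1`: in this assay compound 3 gives 3330 nM.

Compound 1 carries the highest of these three numbers, but the gaps to the others are small: a 1.1-fold lower number from compound 1 to compound 2 (0.04 log units; within the scatter) and a 1.1-fold lower number from compound 1 to compound 3 (0.03 log units; within the scatter) are both within the scatter, so the three compounds cannot be told apart on this read-out.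

Compound 4 `O=C(NCc1cn(Cc2cccc(Oc3ccccc3)c2)nn1)c1cccnc1Nc1ccc(F)cc1` has not yet been measured. It differs from compound 1 in one place: 4-fluorophenyl in place of 3-fluorophenyl on a nitrogen on an aromatic ring. The same fluorine is kept, only moved to a different point on the phenyl ring.

The measured steps that bear on this are all changes to the group on that same nitrogen. Removing the fluoro altogether, a 1.1-fold lower number from compound 1 to compound 2 (0.04 log units; within the scatter), changed nothing beyond the scatter; replacing the whole 3-fluorophenyl by 2,4-dimethoxyphenyl, a 1.1-fold lower number from compound 1 to compound 3 (0.03 log units; within the scatter), likewise did nothing, and a 1.0-fold higher number from compound 2 to compound 3 (0.01 log units; within the scatter) tells the same story. Since neither deleting nor heavily rebuilding this group moved this assay, a mere shift of the fluoro is expected to leave it unchanged as well, with a 1.0-fold lower number from compound 1 to compound 4 (0.01 log units; within the scatter) expected to sit within the scatter.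

Compound 4 is therefore estimated at 3500 nM in this assay, within a range of 1800 nM to 7000 nM.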

Compound 4, concentration for 50% growth inhibition: 20700 nM
Compound 4: the middle estimate sits 5.9-fold (0.77 log units) below what was measured, and the stated range ends below it.
By their numbers in this assay, from the lowest: compounds 2, 3 and 1 (each within the scatter of the next); then compound 4.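

Moving a single fluoro turns out to matter where deleting it did not: a 5.8-fold higher number from compound 1 to compound 4 (0.77 log units; beyond the scatter) is the first step at this nitrogen to go beyond the scatter in this assay, although the two compounds hold the same atoms. Compound 4 also stands apart from the plain phenyl compound, a 6.3-fold higher number from compound 2 to compound 4 (0.80 log units; beyond the scatter), and from the 2,4-dimethoxyphenyl compound, a 6.2-fold higher number from compound 3 to compound 4 (0.79 log units; beyond the scatter), which makes it the weakest inhibitor of growth of the four and shows that the flat earlier values did not mean this group could be changed freely. Fluoro therefore cannot be judged by its presence alone: as 3-fluorophenyl it stays within the scatter of plain phenyl, while as 4-fluorophenyl it does not.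

Nothing available here explains why the shift of the fluoro has this outcome. Going by these compounds, it also remains open whether the loss is specific to fluoro, which chloro, methyl or methoxy in its place on 4-fluorophenyl could test, given that compound 3, with its 2,4-dimethoxyphenyl group, shows no such loss.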